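This account rests on a few compounds, and the source may have more. Where it says the series, first, only, none or still open, it means among the compounds named here.

Measured in a functional assay on QG-56 cells (Homo sapiens) for cytotoxicity, read by MTT assay, with a stated time of 48 h; a higher number here means a weaker inhibitor, a lower number a stronger inhibitor:
- compound 1 `COc1cc(/C=C/C(=O)C2=C(/C=C/c3ccc(O)c(OC)c3)NC(=O)NC2c2ccc(O)cc2)ccc1O`: 50000 nM
- compound 2 `COc1cc(/C=C/C(=O)C2=C(/C=C/c3ccc(O)c(OC)c3)NC(=O)NC2c2c(Cl)cccc2Cl)ccc1O`: 100000 nM
- compound 3 `COc1cc(/C=C/C(=O)C2=C(/C=C/c3ccc(O)c(OC)c3)NC(=S)NC2c2ccccc2)ccc1O`: 100000 nM

Compound 3, at 100000 nM, reads the same as compound 2, and all three compounds lie within the usual scatter of one another. Compound 4 `COc1cc(/C=C/C(=O)C2=C(/C=C/c3ccc(O)c(OC)c3)NC(=S)NC2c2c(Cl)cccc2Cl)ccc1O` differs from compound 3 in one place: 2,6-dichlorophenyl in place of phenyl on a saturated ring carbon.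

For the measured compounds named here, one measured step bears on this change. The same group enters in a 2.0-fold higher number from compound 1 to compound 2 (0.30 log units; within the scatter), where 2,6-dichlorophenyl takes the place of 4-hydroxyphenyl on a saturated ring carbon. That step lies within the scatter. It is only a loose guide, since it starts from a different group and from a carbonyl where compound 3 carries a thiocarbonyl. No step beyond the scatter is therefore expected in this assay, and the estimated change is a 1.1-fold lower number from compound 3 to compound 4 (0.05 log units; within the scatter). For compound 4 the estimated value is 90000 nM, with an expected range of 45000 nM to 180000 nM.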

Compound 4, half-maximal inhibitory concentration: 100000 nM
For compound 4 the middle estimate is 1.1-fold (0.05 log units) below the measured one; the range from low to high includes it.
By their numbers in this assay, from the lowest: compounds 1, 2, 3 and 4 (each within the scatter of the next).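

In this assay the change to 2,6-dichlorophenyl from phenyl on a saturated ring carbon gives no change at the digits printed from compound 3 to compound 4 (within the scatter) and thus stays within the scatter. The earlier step at this position started from 4-hydroxyphenyl and carried a carbonyl, so this result shows the same group entering beside a thiocarbonyl, again with no step beyond the scatter. Compound 2 reads 100000 nM and compound 4 reads 100000 nM, the same printed number with either carbonyl or thiocarbonyl, and nothing available explains these readings.

The compounds shown leave open whether an amine or a carboxylic acid on the phenyl ring at this position would read any differently in this assay as well. Also open, from the compounds shown here alone, is whether a longer chain in place of the ring on this carbon would produce a step beyond the scatter.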